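A few compounds are considered here, and "the series" means these few. Any claim that something is new, unique, unknown or untested is made for them only; others in the source may bear on it.

Among the compounds with values here, compound 3 `COc1ccc(C(c2ccc(O)cc2)c2cccc3ccccc23)c(OC)c1OC` is the only member of this small set with a number: in a functional assay on HCT-116 cells (Homo sapiens) for inhibition, read by sulforhodamine B assay, with a stated time of 48 h (a higher number here means a weaker inhibitor, a lower number a stronger inhibitor), compound 3 gives 16000 nM. Compound 1 `COc1ccc(C(OCc2ccccc2)c2cccc3ccccc23)c(OC)c1OC` reaches only the limit > 20000 nM in this assay. Compound 2 `COc1ccc(C(c2ccc(OCCO)cc2)c2cccc3ccccc23)c(OC)c1OC` likewise reaches only the limit > 20000 nM. Compound 4 `COc1ccc(C(c2ccc(OCC(=O)O)cc2)c2cccc3ccccc23)c(OC)c1OC` differs from compound 3 by carboxymethyl in place of hydrogen on an oxygen on an aromatic ring. The nearest measured step changes that same oxygen in the reverse direction: an at least 1.2-fold lower number from compound 2 to compound 3 (0.09 log units; that floor lies within the scatter), a step read against the limit (the limit of > 20000 nM in this assay, at which 2 of the 3 values shown sit). The step of an at least 1.2-fold lower number from compound 1 to compound 3 (0.09 log units; that floor lies within the scatter) also ends at compound 3 but alters a different part. Adding carboxymethyl is therefore expected to move the number back toward the limit, with the step of a 1.9-fold higher number from compound 3 to compound 4 (0.27 log units; within the scatter). Compound 4 is thus estimated at 30000 nM, in the range 12000 nM to 100000 nM.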

Compound 4, half-maximal inhibitory concentration: 5020 nM
Beside the measured number, compound 4's estimate is 6.0-fold (0.78 log units) above it, outside the stated range (below it).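

At the oxygen on the aromatic ring, carboxymethyl gives the first change shown in this assay that clears the scatter, with a 3.2-fold lower number from compound 3 to compound 4 (0.50 log units; beyond the scatter). The end of the chain on that oxygen also counts, since carboxy in place of hydroxymethyl gives an at least 3.9-fold lower number from compound 2 to compound 4 (0.60 log units; beyond the scatter). Replacing benzyloxy with 4-(carboxymethoxy)phenyl gives an at least 3.9-fold lower number from compound 1 to compound 4 (0.60 log units; beyond the scatter), and this step and the one before it are only floors, set by an assay limit: the limit of > 20000 nM in this assay, at which 2 of the 4 values shown sit.

The compounds shown leave open how a methyl ester, an amide or a longer chain ending in carboxy would fare on this oxygen.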